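A few compounds are considered here, and "the series" means these few. Any claim that something is new, unique, unknown or untested is made for them only; others in the source may bear on it.

Measured so far in a functional assay on DU-145 cells (Homo sapiens) for antiproliferative activity, read by WST assay, with a stated time of 3 days; on this read-out lower numbers stand for stronger inhibition and higher numbers for weaker inhibition:

Compound 1 `CCCN(CCC)CCCOc1c(-c2cc(OC)c(OC)c(OC)c2)oc2ccccc2c1=O` gives > 50000 nM.
Compound 2 `CCCCN(CCCC)CCCOc1c(-c2cc(OC)c(OC)c(OC)c2)oc2ccccc2c1=O` gives 15700 nM.

The result for compound 1 is a limit of the assay and not a number. Within the data shown here, compound 2 therefore holds the only true number so far, which leaves nothing to rank it against except that limit.

The next molecule is compound 3 `CCCCCN(CCCCC)CCCCOc1c(-c2cc(OC)c(OC)c(OC)c2)oc2ccccc2c1=O`. The change from compound 2 is (dipentylamino)methyl in place of dibutylamino on a saturated chain carbon, three bonds along the chain from an oxygen on an aromatic ring. In short, (dipentylamino)methyl takes the place of dibutylamino on a saturated chain carbon, three bonds along the chain from an oxygen on an aromatic ring.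

Among the measured compounds shown here, only one measured step bears on this change: an at least 3.1-fold lower number from compound 1 to compound 2 (0.50 log units; beyond the scatter). That step also replaced the groups on the amine with larger ones, and it lies beyond the scatter. On these data alone, its true size is unknown, since one end is a limit. A single step is thin support, so only a moderate further fall in this assay is expected, and no change remains possible. The expected step is a 2.2-fold lower number from compound 2 to compound 3 (0.35 log units; beyond the scatter). For compound 3 the estimated value is 7000 nM, with an expected range from 2000 nM to 22000 nM.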

Compound 3, half-maximal inhibitory concentration: 12500 nM
For compound 3 the middle estimate is 1.8-fold (0.25 log units) below the measured one, within the range that was stated.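

In this assay, the swap to (dipentylamino)methyl, with 12 heavy atoms against 9 in dibutylamino, gives a 1.3-fold lower number from compound 2 to compound 3 (0.10 log units; within the scatter), so the two compounds cannot be told apart at this position. Measured against dipropylamino, the larger group still gives an at least 4.0-fold lower number from compound 1 to compound 3 (0.60 log units; beyond the scatter), but the fall in the number seen with the earlier change does not clearly continue beyond dibutylamino. On these data alone, the result for compound 1 is a limit, and the full size of any change starting from compound 1 stays unknown because of it: the limit of > 50000 nM in this assay, at which 1 of the 3 values shown sits.

The compounds shown leave open how the amine groups and the chain each contribute, since (dipentylamino)methyl changes both at once, and a dipentylamino group on the chain of compound 2 would separate the two. They also leave open whether a still longer group such as dihexylamino, or a ring amine such as piperidine, would bring the number clearly below that of compound 2 and compound 3.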